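A nitro swap on compound 1

A few compounds are considered here, and "the series" means these few. Any claim that something is new, unique, unknown or untested is made for them only; others in the source may bear on it.

Measured so far:
Compound 1 `COc1cc(/C=C2\CN(S(=O)(=O)c3ccc(NC(C)=O)cc3)C/C(=C\c3cc(OC)c(OC)c(OC)c3)C2=O)cc(OC)c1OC` gives 3470 nM
Compound 2 `COc1cc(/C=C2\CN(S(=O)(=O)c3ccc(F)cc3)C/C(=C\c3ccccc3F)C2=O)cc(OC)c1OC` gives 6340 nM

Both numbers come from a functional assay on SMMC-7721 cells (Homo sapiens) for cytotoxicity, read by MTT assay, with a stated time of 24 h (on this read-out higher numbers stand for weaker inhibition and lower numbers for stronger inhibition), and are the only two available. Compound 1 has the lower number of the pair, but the gap to compound 2 lies within the usual scatter of repeated measurements, so the two cannot be ranked.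

The next compound is compound 3 `COc1cc(/C=C2\CN(S(=O)(=O)c3ccc(NC(C)=O)cc3)C/C(=C\c3cccc([N+](=O)[O-])c3)C2=O)cc(OC)c1OC`, which keeps the core of compound 1 and changes one group: 3-nitrophenyl in place of 3,4,5-trimethoxyphenyl on a double-bonded chain carbon bound to a double-bonded ring carbon. In words, this puts 3-nitrophenyl in place of 3,4,5-trimethoxyphenyl on a double-bonded chain carbon bound to a double-bonded ring carbon.

For the measured compounds named here, no measured pair shows this change on its own, so the data give no direct guide to its size or direction. Going by the values given here, the only anchors are compound 1 at 3470 nM and compound 2 at 6340 nM, which sit close together. On that thin basis, nothing beyond the scatter is expected, and the estimated 1.2-fold higher number from compound 1 to compound 3 (0.06 log units; within the scatter) is small in either direction. In this assay compound 3 is expected near 4000 nM with an estimated range from 1300 nM to 12000 nM as the likely span.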

Compound 3, half-maximal inhibitory concentration: 1950 nM
Compound 3: the middle estimate sits 2.1-fold (0.31 log units) above what was measured; measured number inside the range.
By their numbers in this assay, from the lowest: compounds 3, 1 and 2 (each within the scatter of the next, the first and the last beyond it).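

In this assay, putting 3-nitrophenyl in place of 3,4,5-trimethoxyphenyl on a double-bonded chain carbon bound to a double-bonded ring carbon gives a 1.8-fold lower number from compound 1 to compound 3 (0.25 log units; within the scatter). For the compounds shown here, this is the first comparison here in which only one place differs, and it shows that this position can take two quite different aromatic groups, one with three methoxy groups and one with a single nitro group, without a difference that can be told from ordinary assay variation. No supporting data are available to explain why the two groups read alike in this assay.

A single exchange of this kind says little about the position as a whole, since both groups are substituted phenyl rings and a result within the scatter could hide a small real difference in either direction. On these data alone, it remains open how this position would respond to a phenyl ring carrying an amine or a carboxylic acid, or to a saturated ring such as cyclohexyl in place of the aromatic one.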